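The source may hold more compounds than are shown below. What is called first, only, known or untested is meant among the compounds shown, and "the series" means these compounds.

Measured so far:
- Compound 1 `Clc1ccccc1Cn1nnc2c(NC3CCCCC3)nc(-c3ccccc3)nc21`: 34000000 nM
- Compound 2 `Clc1ccccc1Cn1nnc2c(NC3CCCC3)nc(-c3ccccc3)nc21`: 9000000 nM
- Compound 3 `CCCCCCNc1nc(-c2ccccc2)nc2c1nnn2Cc1ccccc1Cl`: 31000000 nM

All three share one core and differ only in the group carried by the amino nitrogen on the aromatic ring. In an assay on isolated protein for binding affinity to adenosine receptor A1 (Bos taurus) (on this read-out higher numbers stand for weaker inhibition and lower numbers for stronger inhibition), compound 3 gives 31000000 nM, the second highest of the three numbers; its gap to compound 1, a 1.1-fold lower number from compound 1 to compound 3 (0.04 log units; within the scatter), lies within the scatter, while compound 2 stands apart with a 3.4-fold higher number from compound 2 to compound 3 (0.54 log units; beyond the scatter).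

Compound 4 `CC(O)CNc1nc(-c2ccccc2)nc2c1nnn2Cc1ccccc1Cl` takes the next step from compound 3: 1-hydroxyethyl in place of pentyl on a saturated chain carbon bound to a nitrogen on an aromatic ring. The chain on the nitrogen is thus shortened and gains a hydroxyl. The steps seen so far only exchanged one hydrocarbon group for another: going from a six-membered ring to a five-membered ring gave a 3.8-fold lower number from compound 1 to compound 2 (0.58 log units; beyond the scatter), and opening the ring into a chain gave a 1.1-fold lower number from compound 1 to compound 3 (0.04 log units; within the scatter). For the measured compounds named here, no measured step introduces a hydroxyl, so its effect is unknown here. Given the modest size of the steps seen, compound 4 is expected to move only modestly in this assay, a 1.6-fold lower number from compound 3 to compound 4 (0.19 log units; within the scatter), with the direction uncertain. The estimate for compound 4 is 20000000 nM, within 5000000 nM to 80000000 nM.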

Compound 4, inhibition constant: 32000000 nM
The estimate for compound 4 lay 1.6-fold (0.20 log units) below the measured number; measured number inside the range.
By their numbers in this assay, from the lowest: compound 2; then compounds 3, 4 and 1 (each within the scatter of the next).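

In this assay, the shorter 2-hydroxypropyl chain, with its hydrogen-bond donor and acceptor, cannot be told apart from the hexyl chain it replaces (a 1.0-fold higher number from compound 3 to compound 4 (0.01 log units; within the scatter)) or from the cyclohexyl group (a 1.1-fold lower number from compound 1 to compound 4 (0.03 log units; within the scatter)). For the compounds shown here, the first group here that is not a pure hydrocarbon therefore reads like these two, while the cyclopentyl group of compound 2 still stands apart (a 3.6-fold higher number from compound 2 to compound 4 (0.55 log units; beyond the scatter)). No measurement here accounts for these numbers.

Compound 4 differs from compound 3 in both chain length and the hydroxyl, so a plain propyl chain would be needed to separate the two changes. On these data alone, how an amine or a carboxylic acid on the chain would read at this position also stays open.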